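The source may hold more compounds than are shown below. What is called first, only, known or untested is meant among the compounds shown, and "the series" means these compounds.

Measured in a physicochemical assay for lipophilicity, at pH 7.4; on this read-out higher numbers stand for higher lipophilicity and lower numbers for lower lipophilicity:

- compound 1, `O=C(Cc1nn(C2CCNC2)c(=O)c2ccccc12)Nc1ccc(OC(F)(F)F)c(Cl)c1`: 3.03
- compound 2, `COc1cc(OC)c(NC(=O)Cc2nn(CC(=O)O)c(=O)c3ccccc23)cc1Cl`: 1.64
- compound 3, `O=C(O)Cn1nc(Cc2cn3cc(OCC4CC4)c(Cl)cc3n2)c2ccccc2c1=O`: 2.27

Compound 2 stands lowest of the three numbers in this assay. The nearest of the others is compound 3, which lies higher by a gap beyond the usual scatter; compound 1 lies furthest above, again beyond the scatter. Among the measured compounds shown here, no pair among the measured compounds differs in only one place, so no single-point step has been measured in this set, and these three values show only that the carboxylic acid compounds 2 and 3 sit below compound 1.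

Compound 4, `COc1ccc(Cl)cc1NC(=O)Cc1nn(CC(=O)O)c(=O)c2ccccc12`, is the unmeasured neighbour of compound 2. The change is hydrogen in place of methoxy on an aromatic carbon.

Expectation for the step: a group with one hydrogen-bond acceptor and two heavy atoms is removed from the aromatic ring of compound 2 and nothing beyond a hydrogen replaces it. For a change of this kind the step in this assay is expected to be small and, if anything, upward, most likely within the scatter of repeated measurements.

Compound 4 is therefore estimated at 1.8 in this assay, with a range from 1.4 to 2.3, which means an expected step of a number 0.16 log units higher from compound 2 to compound 4 (within the scatter) from compound 2.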

Compound 4, distribution coefficient: 1.9
Compound 4: the middle estimate sits 0.10 log units below what was measured; low and high end bracket the measured number.
By their numbers in this assay, from the lowest: compounds 2 and 4 (each within the scatter of the next); then compound 3; then compound 1.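

In this assay, among the compounds shown here, hydrogen in place of methoxy on an aromatic carbon gives a number 0.26 log units higher from compound 2 to compound 4 (within the scatter), the only step in the set that changes a single place. For the compounds shown here, the group that leaves sits ortho to a chloro group and meta to a methoxy group on a six-membered aromatic ring of carbon only, so this pair gives the series its one direct reading at this position: with the rest of compound 2 held constant, removing this methoxy group does not move the read-out beyond the scatter. No evidence is available on what lies behind the size of this step.

On these data alone, whether this holds for other groups at the same position remains open, as only methoxy and hydrogen have been compared there, and a hydroxyl, a fluoro group, a nitrile or a longer alkoxy chain could behave differently. Also open, as far as these compounds go, is whether the step carries over to a compound without the carboxylic acid side chain, since compound 1 and compound 3 each differ from compound 2 in more than one place and cannot answer this.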